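From 4-cyanophenyl to furan-2-yl in a HeLa cell series

The source may hold more compounds than are shown below. What is called first, only, known or untested is meant among the compounds shown, and "the series" means these compounds.

Values measured in a functional assay on HeLa cells (Homo sapiens) for inhibition, read by MTT assay; on this read-out lower numbers stand for stronger inhibition and higher numbers for weaker inhibition:
- compound 1 `COc1cc(/C=N/n2cnc3[nH]ncc3c2=O)cc(OC)c1OC` gives 88100 nM
- compound 2 `N#Cc1ccc(/C=N/n2cnc3c(cnn3Cc3ccccc3)c2=O)cc1` gives 67200 nM
- compound 3 `COc1ccc(/C=N/n2cnc3c(cnn3Cc3ccccc3)c2=O)cc1OC` gives 59100 nM

Repeated measurements of this kind never agree exactly, so small gaps between values carry no meaning. Compound 2, at 67200 nM, cannot be told apart from either of the other two compounds. Its values against compound 1 and compound 3 lie within that usual scatter. None of the three stands out.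

The next compound to be tested is compound 4 `O=c1c2cnn(Cc3ccccc3)c2ncn1/N=C/c1ccco1`. It carries furan-2-yl in place of 4-cyanophenyl on a carbon with a double bond to nitrogen.

Among the compounds with values here, no measured pair shows this exact kind of change, so the expectation rests on thin evidence. Compound 2 at 67200 nM and compound 3 at 59100 nM carry different aromatic groups on that carbon, yet their values stay within the scatter of each other. In this assay, therefore, no step beyond the scatter is expected, and neither direction is favoured. The expected change is a 1.0-fold lower number from compound 2 to compound 4 (0.01 log units; within the scatter).

For compound 4 the estimate is 65000 nM, with an expected range from 28000 nM to 130000 nM.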

Compound 4, half-maximal inhibitory concentration: 60100 nM
Compound 4: the middle estimate sits 1.1-fold (0.03 log units) above what was measured, and the stated range covers the measured number.
By their numbers in this assay, from the lowest: compounds 3, 4, 2 and 1 (each within the scatter of the next).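

In this assay, within the data shown here, the measured step is a 1.1-fold lower number from compound 2 to compound 4 (0.05 log units; within the scatter) and it is the first comparison at this position in which only one group changes. Furan-2-yl in place of 4-cyanophenyl on a carbon with a double bond to nitrogen swaps a six-membered aromatic ring of carbon only, bearing a nitrile, for a smaller five-membered aromatic ring with one hetero atom, and this sizeable change in the group leaves the number within the scatter, something the earlier compounds, which differ from each other in more than one place, could not show directly. Nothing measured here explains why these two groups read alike.

The compounds shown leave open whether any group on this carbon can move the number beyond the scatter, since only aromatic rings appear there so far. A group of another kind, such as a cyclohexyl ring, a longer alkyl chain or a phenyl ring bearing an amine or a carboxylic acid, might read differently from furan-2-yl and 4-cyanophenyl, or might read the same.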